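The compounds below may be only part of what the source reports. "The series", "measured", "known", "first", "only" and "open" are said of these compounds alone.

Working notes on the series. Compound 1 `Cc1cc(C#N)cc(C)c1Oc1nc(Nc2ccc(C#N)cc2)ncc1/C=C/C(=O)NC1CCN(S(C)(=O)=O)CC1` is the parent amide of the set. In an ADME assay on TZM cells (Homo sapiens) for cytotoxicity, with a stated time of 1 days (a higher number here means that more compound is tolerated, a lower number that less compound is tolerated), compound 1 gives > 175 nM, which is a limit of the assay and not a number. Compound 2 `Cc1cc(C#N)cc(C)c1Oc1nc(Nc2ccc(C#N)cc2)ncc1/C=C/C(=O)NC1CCN(S(=O)(=O)C(F)(F)F)CC1` differs from compound 1 by trifluoromethyl in place of methyl on a sulfonyl sulfur. In this assay compound 2 gives > 160 nM, again only a limit. Compound 3 `Cc1cc(C#N)cc(C)c1Oc1nc(Nc2ccc(C#N)cc2)ncc1/C=C/C(=O)N1CCN(S(C)(=O)=O)CC1` differs from compound 1 by 4-(methylsulfonyl)piperazin-1-yl in place of (1-(methylsulfonyl)piperidin-4-yl)amino on a carbonyl carbon, which is also how the core of compound 3 departs from the core of compound 1. In this assay compound 3 gives > 179 nM, once more a limit. The measured steps a step that the two limits leave unreadable from compound 1 to compound 2 and a step that the two limits leave unreadable from compound 1 to compound 3 therefore have no readable size; the three values simply rest at the limit of > 160 nM in this assay, at which 1 of the 3 values shown sits, the limit of > 175 nM in this assay, at which 1 of the 3 values shown sits, and (the limit of > 179 nM in this assay, at which 1 of the 3 values shown sits).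

Compound 4 `Cc1cc(C#N)cc(C)c1Oc1nc(Nc2ccc(C#N)cc2)ncc1/C=C/C(=O)N1CCN(S(=O)(=O)C(F)(F)F)CC1` is not yet measured. It differs from compound 3 by trifluoromethyl in place of methyl on a sulfonyl sulfur, the same change as from compound 1 to compound 2, at the same place in the same words. Resting on a step that the two limits leave unreadable from compound 1 to compound 2, which the two limits left unreadable, the expected step in this assay is an at least 1.0-fold lower number from compound 3 to compound 4 (0.02 log units; that floor lies within the scatter), essentially flat. Compound 4 is accordingly estimated at 170 nM, most likely to be reported once more as a limit rather than a number.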

Compound 4, half-maximal cytotoxic concentration: > 164 nM
Compound 4 was reported as a limit; the forecaster's own chance of this, stated with the estimate: 85%; the middle value does not contradict the limit.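

In this assay compound 4 gives > 164 nM, again a limit and not a number. Compound 3 and compound 4 both rest at limits, and the step between them cannot be read. The compounds shown leave open the concentration at which any of the four becomes cytotoxic, and whether trifluoromethyl in place of methyl on a sulfonyl sulfur changes it.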